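From Methylsulfanyl to Imidazolyl: Expecting Compound 4

This account rests on a few compounds, and the source may have more. Where it says the series, first, only, none or still open, it means among the compounds named here.

Of the compounds shown here, three have been measured in a functional assay on U-87MG ATCC cells for inhibition, with U-87 MG (Homo sapiens) as the target, read by sulforhodamine B assay, with a stated time of 72 h; on this read-out lower numbers stand for an effect already at smaller amounts and higher numbers for an effect only at larger amounts of compound. Compound 1 `CCC(=O)Oc1cccc2ccc(/C=C/c3ccccc3[N+](=O)[O-])nc12` gives 10500 nM, compound 2 `O=C(/C=C/c1ccc([N+](=O)[O-])o1)c1ccc(Br)cc1` gives 12600 nM, and compound 3 `CSc1ccc(C(=O)/C=C/c2ccc([N+](=O)[O-])o2)cc1` gives 3900 nM, the lowest of the three numbers. Going by the values given here, the only step that can be traced between two measured compounds is a 3.2-fold lower number from compound 2 to compound 3 (0.51 log units; beyond the scatter). Compound 4 `O=C(/C=C/c1ccc([N+](=O)[O-])o1)c1ccc(-n2ccnc2)cc1` has not yet been measured; it differs from compound 3 in one place: 1H-imidazol-1-yl in place of methylsulfanyl on an aromatic carbon. Among the compounds with values here, no measured step bears directly on this exchange, as the single known step concerns bromo and methylsulfanyl only. With nothing to guide the direction, the expectation for compound 4 in this assay is a number close to that of compound 3, a step of a 1.3-fold higher number from compound 3 to compound 4 (0.11 log units; within the scatter), and the estimate is 5000 nM, within a range from 1800 nM to 14000 nM.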

Compound 4, half-maximal effective concentration: 13400 nM
For compound 4 the middle estimate is 2.7-fold (0.43 log units) below the measured one; the measured number falls inside the stated range.
By their numbers in this assay, from the lowest: compound 3; then compounds 1, 2 and 4 (each within the scatter of the next).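

Putting 1H-imidazol-1-yl in place of methylsulfanyl gives a 3.4-fold higher number from compound 3 to compound 4 (0.54 log units; beyond the scatter) in this assay and so removes the advantage methylsulfanyl held at this position, para to a large group. Set against bromo, the same ring gives a 1.1-fold higher number from compound 2 to compound 4 (0.03 log units; within the scatter) and the two groups stand level, which leaves methylsulfanyl alone among the three groups compared here. No measurement at hand explains why methylsulfanyl stands apart. As far as these compounds go, it remains open whether a longer sulfur chain such as ethylsulfanyl, or a methoxy group with oxygen in place of sulfur, would keep the lower number.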